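The source may hold more compounds than are shown below. What is called first, only, known or untested is meant among the compounds shown, and "the series" means these compounds.

Growth inhibition in a functional assay on SK-MEL-5 cells (Homo sapiens) for cytotoxicity, read by sulforhodamine B assay, with a stated time of 48 h (on this read-out higher numbers stand for weaker inhibition of growth and lower numbers for stronger inhibition of growth), for the measured members of the series:

compound 1 `ClCc1ccccc1Cn1cnc2c(Cl)nc(Cl)nc21`: 1540 nM
compound 2 `ClCc1ccccc1Cn1cnc2c(Cl)ncnc21`: 2880 nM
compound 3 `ClCc1cccc(Cn2cnc3c(Cl)nc(Cl)nc32)c1`: 3020 nM

Going by the values given here, compound 2 sits among the three with no separation beyond the scatter: its gap to compound 3 is negligible, and the only single-point step, a 1.9-fold higher number from compound 1 to compound 2 (0.27 log units; within the scatter), is also within the scatter. Compound 4 `Nc1nc(Cl)c2ncn(Cc3ccccc3CCl)c2n1` differs from compound 2 by amino in place of hydrogen on an aromatic carbon. Among the compounds with values here, the one measured step touching this carbon, from compound 1 to compound 2, shifted nothing beyond the scatter, and no measured pair shows an amino entering anywhere. The step of a 1.2-fold lower number from compound 2 to compound 4 (0.06 log units; within the scatter) is therefore expected to stay within the scatter, with no direction assumed. Compound 4 is expected near 2500 nM, within 900 nM to 7000 nM.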

Compound 4, concentration for total growth inhibition: 26300 nM
Beside the measured number, compound 4's estimate is 11-fold (1.02 log units) below it; measured number outside the range, above it.
By their numbers in this assay, from the lowest: compounds 1, 2 and 3 (each within the scatter of the next); then compound 4.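

At this carbon between two ring nitrogen atoms, the read-out in this assay does respond to substitution: amino gives a 9.1-fold higher number from compound 2 to compound 4 (0.96 log units; beyond the scatter), and measured against chloro it gives a 17-fold higher number from compound 1 to compound 4 (1.23 log units; beyond the scatter). The earlier exchange of chloro and hydrogen here stayed within the scatter, so the change appears only with amino among the groups shown. No data shown account for this shift.

Going by these compounds, whether a methoxy or dimethylamino group on this carbon would behave like amino remains open. Also open, on these data alone, is whether amino has a similar effect with the chloromethyl placement of compound 3.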